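An Ester Becomes an Amide: Expecting Compound 4

The source may hold more compounds than are shown below. What is called first, only, known or untested is meant among the compounds shown, and "the series" means these compounds.

Compound 1 `COC(=O)c1nc(Br)c2cccnc2c1N[C@H]1CC[C@H](N)CC1` is the starting point. In a functional assay on MDA-MB-435 cells (Homo sapiens) for cytotoxicity, read by MTT assay, with a stated time of 72 h (on this read-out lower numbers stand for stronger inhibition and higher numbers for weaker inhibition), compound 1 gives only a limit, > 20000 nM, so its potency sits somewhere past (the limit of > 20000 nM in this assay, at which 1 of the 3 values shown sits). Compound 4 `C[C@H](NC(=O)c1nc(Br)c2cccnc2c1N[C@H]1CC[C@H](N)CC1)c1ccc(F)cc1` differs from compound 1 in one place: (1-(4-fluorophenyl)ethyl)amino in place of methoxy on a carbonyl carbon. Among the measured compounds shown here, no measured pair makes exactly this change. For the measured compounds named here, the only measured step, a 2.0-fold lower number from compound 2 to compound 3 (0.30 log units; within the scatter), alters a different substituent and is within the scatter, so it says nothing about the carbonyl carbon. Compound 2 `COC(=O)CNc1c(C(=O)NCc2ccc(F)cc2)nc(Br)c2cccnc12` and compound 3 `NCCCNc1c(C(=O)NCc2ccc(F)cc2)nc(Br)c2cccnc12`, which both carry an amide rather than a methoxycarbonyl group on that carbonyl carbon, do give measurable numbers: compound 2 gives 10000 nM and compound 3 gives 5000 nM in this assay. For compound 4 a step of an at least 6.6-fold lower number from compound 1 to compound 4 (0.82 log units; beyond the scatter) toward stronger inhibition is therefore expected, with an estimate of 3000 nM and a range of 800 nM to 15000 nM.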

Compound 4, half-maximal inhibitory concentration: > 10000 nM
Compound 4 gave a limit, no number; the forecaster's own chance of this, stated with the estimate: 15%; middle value at least 3.3-fold (0.52 log units) away from the limit.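

Among the compounds shown here, compound 1 and compound 4 each give only a limit in this assay, and no step between them can be read. On these data alone, whether (1-(4-fluorophenyl)ethyl)amino in place of methoxy on a carbonyl carbon changes potency at all remains open.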